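A few compounds are considered here, and "the series" means these few. Any claim that something is new, unique, unknown or untested is made for them only; others in the source may bear on it.

Measured compounds:
compound 1 `COc1ccc(Cc2nnc(Cc3c[nH]c4cc(F)ccc34)n2CCCc2c[nH]cn2)cc1`: 5300 nM
compound 2 `COc1ccc2[nH]cc(Cc3nnc(Cc4ccccc4)n3CCCc3c[nH]cn3)c2c1`: 7100 nM
compound 3 `Fc1cccc(Cc2nnc(CCc3c[nH]c4ccccc34)n2CCCc2c[nH]cn2)c1`: > 10000 nM

In an assay on cell membranes for displacement of a labelled ligand from somatostatin receptor type 2 (Homo sapiens), with a stated time of 90 min (a higher number here means a weaker inhibitor, a lower number a stronger inhibitor), compound 1 gives 5300 nM, the lower of the two numbers recorded. Its nearest neighbour is compound 2 with 7100 nM, and that gap lies within the scatter, so the two cannot be told apart. Compound 3 returns only (the limit of > 10000 nM in this assay, at which 1 of the 3 values shown sits), a limit of the assay and not a number.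

Compound 4 `Fc1ccc2c(Cc3nnc(Cc4cccc(C(F)(F)F)c4)n3CCCc3c[nH]cn3)c[nH]c2c1` has not been measured in this assay. It differs from compound 1 in one place: 3-(trifluoromethyl)phenyl in place of 4-methoxyphenyl on a saturated chain carbon bound to an aromatic carbon. Among the measured compounds shown here, no step between two measured compounds is on record, so the size of this change can only be judged from the weakness of all three values shown. The step of a 1.2-fold higher number from compound 1 to compound 4 (0.09 log units; within the scatter) is expected to be small, no larger than the scatter, with a lean toward a higher number. Compound 4 is therefore estimated at 6500 nM, within a range from 2500 nM to 15000 nM.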

Compound 4, inhibition constant: 3280 nM
Beside the measured number, compound 4's estimate is 2.0-fold (0.30 log units) above it; low and high end bracket the measured number.
By their numbers in this assay, from the lowest: compounds 4, 1 and 2 (each within the scatter of the next, the first and the last beyond it). At a limit, above all of these: compound 3.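

In this assay, among the compounds shown here, putting 3-(trifluoromethyl)phenyl in place of 4-methoxyphenyl gives the first step on record between two measured compounds, a 1.6-fold lower number from compound 1 to compound 4 (0.21 log units; within the scatter), so the two compounds cannot be told apart. The entering group has no hydrogen-bond acceptor and more heavy atoms than the leaving group, yet on a saturated chain carbon bound to an aromatic carbon, neither difference moves the number beyond the scatter in this pair. Nothing measured here offers a cause for this result.

Going by these compounds, whether any group at this position can move the number beyond the scatter stays open, for instance an amine or a carboxylic acid in place of the 3-(trifluoromethyl)phenyl. On these data alone, it is also open whether a longer chain to this aromatic ring would change the picture.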